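Moving the Fluorine Pattern on the Benzyl Group

A few compounds are considered here, and "the series" means these few. Any claim that something is new, unique, unknown or untested is made for them only; others in the source may bear on it.

Compound 1 `Cc1cc(Nc2nc(NCc3ccc(F)cc3)nc3ccccc23)n[nH]1` gives 20 nM in an assay for inhibition of high affinity nerve growth factor receptor (Homo sapiens), read by HTRF, with a stated time of 30 min, in the presence of a further agent that is not named here (on this read-out lower numbers stand for stronger inhibition and higher numbers for weaker inhibition), the lowest of the three numbers recorded there. Compound 2 `Cc1cc(Nc2nc(NCc3ccc(C#N)cc3)nc3ccccc23)n[nH]1` gives 83 nM in this assay, and compound 3 `Cc1cc(Nc2nc(NCc3ccc(F)cc3F)nc3ccccc23)n[nH]1` gives 200 nM. The measured steps all run upward from compound 1: a 4.2-fold higher number from compound 1 to compound 2 (0.62 log units; beyond the scatter) and a 10-fold higher number from compound 1 to compound 3 (1.00 log units; beyond the scatter), while between the two weaker compounds a 2.4-fold higher number from compound 2 to compound 3 (0.38 log units; beyond the scatter).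

Compound 4 `Cc1cc(Nc2nc(NCc3cc(F)cc(F)c3)nc3ccccc23)n[nH]1` has not yet been measured. It differs from compound 1 in one place: 3,5-difluorophenyl in place of 4-fluorophenyl on a saturated chain carbon bound to a nitrogen on an aromatic ring. The step from compound 1 to compound 3 bears most directly on this, since it also adds a second fluorine to the same ring and gave a clearly higher number; the step from compound 1 to compound 2 shows that altering the single substituent on that ring also raised the number. Compound 4 is therefore expected to read higher than compound 1, with a step estimated as a 4.0-fold higher number from compound 1 to compound 4 (0.60 log units; beyond the scatter). For compound 4 the estimate in this assay is 80 nM, with a range from 25 nM to 300 nM.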

Compound 4, half-maximal inhibitory concentration: 170 nM
Beside the measured number, compound 4's estimate is 2.1-fold (0.33 log units) below it, and the stated range covers the measured number.
By their numbers in this assay, from the lowest: compound 1; then compound 2; then compounds 4 and 3 (each within the scatter of the next).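

In this assay, the position of the second fluorine made no readable difference: a 1.2-fold lower number from compound 3 to compound 4 (0.07 log units; within the scatter), so the 3,5-difluorophenyl and 2,4-difluorophenyl groups cannot be ranked against each other. Both difluoro patterns sit well above the 4-fluorophenyl group, with an 8.5-fold higher number from compound 1 to compound 4 (0.93 log units; beyond the scatter), which means that the rise seen earlier with compound 3 is not confined to one fluorine pattern, and the 4-cyanophenyl group still reads lower than the new group, with a 2.0-fold higher number from compound 2 to compound 4 (0.31 log units; beyond the scatter). No measurement is available here that would explain these differences.

The compounds shown leave open how the plain phenyl group, with no substituent, would read on this saturated chain carbon. They also leave open whether a chloro, methoxy or aminomethyl group on that ring would keep the number near that of compound 1.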